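The compounds below may be only part of what the source reports. "The series", "measured", "known", "first", "only" and "open" are said of these compounds alone.

Working notes on the series. For the measured compounds named here, in a functional assay on HeLa cells (Homo sapiens) for inhibition, read by CCK-8 assay, with a stated time of 48 h (a lower number here means a stronger inhibitor, a higher number a weaker inhibitor), compound 1 (`COc1ccc(Oc2ccc(C(C)C)cc2-c2ccsc2S(=O)(=O)NCCNC(=O)Nc2cc(Cl)cc(Cl)c2)cc1OC`) gives 11600 nM as the only true number so far. Compound 2 (`COc1ccc(NC(=S)NCCNS(=O)(=O)c2sccc2-c2ccc(C)cc2Oc2ccc(O)c(O)c2)cc1`) gives > 20000 nM which is a limit and not a number. Compound 3 (`COc1ccc(Oc2ccccc2-c2ccsc2S(=O)(=O)N2CCN(C(=O)Nc3cccc([N+](=O)[O-])c3)CC2)cc1OC`) gives > 50000 nM which is also a limit. Compound 2 thus stands at the limit of > 20000 nM in this assay, at which 1 of the 3 values shown sits, and cannot be ranked more closely. Compound 4 (`Cc1ccc(-c2ccsc2S(=O)(=O)NCCNC(=S)Nc2ccc([N+](=O)[O-])cc2)c(Oc2ccc(O)c(O)c2)c1`) carries nitro in place of methoxy on an aromatic carbon, para to a large group, as counted in nitro in place of methoxy on an aromatic carbon for the pair. Going by the values given here, no measured step covers this change, so any expectation is loose. The step of an at least 1.3-fold lower number from compound 2 to compound 4 (0.12 log units; that floor lies within the scatter) is expected to be small and toward stronger inhibition, possibly no larger than the scatter. For compound 4 the estimate is 15000 nM with an expected range of 5000 nM to 50000 nM in this read-out.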

Compound 4, half-maximal inhibitory concentration: 6800 nM
Estimate against measurement, compound 4: 2.2-fold (0.34 log units) above; the range from low to high includes it.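

In this assay the series now has its first step at this position, for nitro in place of methoxy para to a large group: an at least 2.9-fold lower number from compound 2 to compound 4 (0.46 log units; beyond the scatter). Compound 2 gives > 20000 nM, which is a limit, so the true size of this step remains a floor. No measurement shown accounts for the step.

This single pair leaves open whether a nitrile or a carboxylic acid on the same aromatic carbon would give a lower or a higher number than nitro. It also leaves open whether the same change gives a similar step in a compound with another linking chain.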